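The source may report more compounds than this note shows. Statements on the series, on what has been measured and on what is new or still open speak of the compounds shown alone.

Measured compounds:
- compound 1, `Nc1nc([SeH])nc2ncccc12`, 36300 nM
- compound 2, `[SeH]c1nc([SeH])c2cccnc2n1`, "not determined" (no result reported)

Going by the values given here, compound 1, `Nc1nc([SeH])nc2ncccc12`, is the only compound with a number in a functional assay on HT-29 cells (Homo sapiens) for cytotoxicity, read by MTT assay, with a stated time of 72 h; on this read-out lower numbers stand for stronger inhibition of growth and higher numbers for weaker inhibition of growth: in this assay compound 1 gives 36300 nM, a weak effect. Compound 2, `[SeH]c1nc([SeH])c2cccnc2n1`, shares the core but carries a second selenol in place of the amine and has no result in this assay, so it offers no comparison. Compound 1 therefore stands alone, with nothing measured beside it.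

Compound 3, `C[Se]c1nc(N)c2cccnc2n1`, is the next step from compound 1: methyl in place of hydrogen on a selenium, that is, a methyl on the selenium whose other neighbour is an aromatic carbon, the amine left in place. Among the compounds with values here, no step between measured compounds exists that would show what such a change does on this core, so the size of the step can only be guessed. The account expects no change beyond the usual scatter, and the estimate for the step from compound 1 to compound 3 in this assay is a 1.2-fold lower number from compound 1 to compound 3 (0.08 log units; within the scatter). Within the data shown here, for compound 3 the expected value is 30000 nM, in a range from 8000 nM to 120000 nM, the wide range reflecting that only one number anchors it.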

Compound 3, concentration for 50% growth inhibition: 44100 nM
Estimate against measurement, compound 3: 1.5-fold (0.17 log units) below; measured number inside the range.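

In this assay, methyl in place of hydrogen on a selenium gives a 1.2-fold higher number from compound 1 to compound 3 (0.08 log units; within the scatter), so compound 1 and compound 3 cannot be told apart on this read-out. Going by these compounds alone, this is the first measured step on the shared core, and it shows that at this position, on a selenium whose other neighbour is an aromatic carbon, the hydrogen is not needed for the weak growth inhibition seen with compound 1: one methyl can take its place with the result staying within the scatter. Nothing available explains this result, and the pair alone gives no reason for it.

Going by these compounds, what a longer chain on that selenium, such as ethyl or benzyl, would do remains open, since a single methyl says little about larger groups at this place. On these data alone, the part played by the amine, which stays in place in both compound 1 and compound 3, is equally open, as is whether a hydroxyl group there, or a sulfur in place of the selenium, would move the number beyond the scatter.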